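A few compounds are considered here, and "the series" means these few. Any claim that something is new, unique, unknown or untested is made for them only; others in the source may bear on it.

Working notes on the series.

Of the compounds shown here, two have been measured in an assay for inhibition of ectonucleoside triphosphate diphosphohydrolase 2 (Homo sapiens), read by malachite green, with a stated time of 10 min (a higher number here means a weaker inhibitor, a lower number a stronger inhibitor), and both sit at an assay limit rather than at a number. Compound 1, `O=c1c(Br)c(C(F)(F)F)[nH]c2c(Br)cccc12`, gives > 300000 nM in this assay, which is a limit. Compound 2, `FC(F)(F)c1nc2c(Br)cccc2c(Cl)c1Br`, gives > 300000 nM in this assay, again a limit. The only evidence on the set is therefore (the limit of > 300000 nM in this assay, at which 2 of the 2 values shown sit); no step between measured compounds can be sized, and nothing separates compound 1 from compound 2 on the numbers shown.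

Compound 3, `FC(F)(F)c1nc2c(-c3ccsc3)cccc2c(Cl)c1Br`, is the unmeasured follow-up. It differs from compound 2 by thiophen-3-yl in place of bromo on an aromatic carbon: a thiophen-3-yl in place of bromo on an aromatic carbon, the ring entering on a six-membered aromatic ring of carbon only, part of a fused system of two rings, ortho and meta to a fused ring. For the measured compounds named here, no measured step of this kind is available, so the direction of the move in this assay is open; the expectation is for a step from compound 2 to compound 3 of an at least 2.0-fold lower number from compound 2 to compound 3 (0.30 log units; that floor lies within the scatter), downward from the limit but with real doubt. For compound 3 the estimate in this assay is 150000 nM, within 20000 nM to 300000 nM, with a fair chance that only a limit is reported again.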

Compound 3, half-maximal inhibitory concentration: > 300000 nM
Compound 3: only a limit was reported (the forecaster's own chance of this, stated with the estimate: 55%); at least 2.0-fold (0.30 log units) between middle value and limit.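

In this assay compound 3 gives > 300000 nM, a limit, and compound 2 also sits at a limit, so the step between compound 2 and compound 3 cannot be read. The compounds shown leave open whether thiophen-3-yl in place of bromo changes inhibition in either direction, and the set offers only one reading: the limit of > 300000 nM in this assay, at which 3 of the 3 values shown sit.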